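Same Atoms, Opposite Handedness at the Oxolane Carbon

This account rests on a few compounds, and the source may have more. Where it says the series, first, only, none or still open, it means among the compounds named here.

Compound 1 `CC[C@@H]1C(=O)N(C)c2cnc(-n3ccnc3-c3ccccc3)nc2N1[C@@H]1CCOC1` stands lowest of the three compounds in a physicochemical assay for lipophilicity; a higher number here means a more lipophilic compound, a lower number a more polar compound: compound 1 gives 1.8. Compound 3 `CC[C@@H]1C(=O)N(C)c2cnc(-n3ccnc3-c3ccccc3)nc2N1CCC(F)(F)F` gives 3.1 in this assay, and compound 2 `CCC1C(=O)N(C)c2cnc(-n3ccnc3-c3ccc(F)cc3)nc2N1c1ccc(F)cc1` gives 3.4 in this assay, both well clear of compound 1.

Among the compounds with values here, the only measured single-point step, a number 1.30 log units higher from compound 1 to compound 3 (beyond the scatter), came from exchanging one group on the ring nitrogen for another, so atoms left and others entered. Compound 4 `CC[C@@H]1C(=O)N(C)c2cnc(-n3ccnc3-c3ccccc3)nc2N1[C@H]1CCOC1` is built in a different way: the two compounds have the same atoms and bonds and differ only in configuration as drawn: 1 of 2 stereo elements differ; a stereocentre at a saturated ring carbon is drawn R in compound 1 and S in compound 4.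

Within the data shown here, no measured step bears directly on a change of drawn configuration alone; the large step seen above required a change of atoms, and here nothing leaves and nothing enters. On these numbers, then, no step beyond the scatter is expected in this assay from compound 1 to compound 4, and the expected step of no change at the digits printed from compound 1 to compound 4 (within the scatter) lies inside that scatter. Compound 4 is expected to give 1.8 in this assay, somewhere between 1.5 and 2.1.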

Compound 4, partition coefficient: 1.9
The estimate for compound 4 lay 0.10 log units below the measured number, within the range that was stated.
By their numbers in this assay, from the lowest: compounds 1 and 4 (each within the scatter of the next); then compounds 3 and 2 (each within the scatter of the next).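

Drawing the stereocentre at the saturated ring carbon of the oxolan-3-yl group the other way gives a step in this assay of a number 0.10 log units higher from compound 1 to compound 4 (within the scatter), so at this position R and S cannot be told apart by this measurement. The step for the exchange of groups on that nitrogen, with the other hand of oxolan-3-yl in place, is a number 1.20 log units lower from compound 3 to compound 4 (beyond the scatter), which shows that the large gap to 3,3,3-trifluoropropyl does not rest on one drawn configuration. The comparison isolates handedness at this carbon, and its basis is a single structural fact: the fact that compounds 1 and 4 differ only in the configuration as drawn

The compounds shown leave open whether changing the other stereo element, which compounds 1 and 4 share, would also stay within the scatter in this assay. They also leave open whether the two hands of pyrrolidin-3-yl, a ring holding an amine where oxolan-3-yl holds its oxygen, would lie as close together.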